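This account rests on a few compounds, and the source may have more. Where it says the series, first, only, none or still open, it means among the compounds named here.

Compound 1 `CCNC(=O)/C=C/C=C/[C@H](O)Cc1ccc(OC)c(OC)c1`: 14600 nM
Compound 2 `COc1ccc(C[C@@H](O)/C=C/C=C/C(=O)N2CCN(C)CC2)cc1OC`: 16500 nM

Both compounds were tested in a functional assay on HeLa cells (Homo sapiens) for antiproliferative activity, read by sulforhodamine B assay, with a stated time of 48 h; a lower number here means a stronger inhibitor, a higher number a weaker inhibitor. On these two numbers compound 2 gives the higher one, with compound 1 close by, and the gap between them is within the scatter. Among the compounds with values here, the only measured step, a 1.1-fold higher number from compound 1 to compound 2 (0.05 log units; within the scatter), changes the group on the carbonyl carbon and moves the number hardly at all.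

Compound 3 `COc1ccc(C[C@@H](O)/C=C/C=C/C(=O)N2CCCC2)cc1OC` differs from compound 2 at the same place: pyrrolidin-1-yl in place of 4-methylpiperazin-1-yl on a carbonyl carbon. Within the data shown here, since the one step that swaps a group on that carbonyl carbon, a 1.1-fold higher number from compound 1 to compound 2 (0.05 log units; within the scatter), stayed within the scatter, the same kind of swap is expected to leave the number about where it is, with no step beyond the scatter in either direction.

Compound 3 is therefore expected to give 15000 nM in this assay, a step of a 1.1-fold lower number from compound 2 to compound 3 (0.04 log units; within the scatter), with a plausible range from 6000 nM to 40000 nM.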

Compound 3, half-maximal inhibitory concentration: 14100 nM
Estimate against measurement, compound 3: 1.1-fold (0.03 log units) above, and the stated range covers the measured number.
By their numbers in this assay, from the lowest: compounds 3, 1 and 2 (each within the scatter of the next).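

The carbonyl carbon has now carried three different groups, and the number has stayed in one place through all of them in this assay. Going from 4-methylpiperazin-1-yl to the smaller pyrrolidin-1-yl ring, which has one ring nitrogen instead of two, gives a 1.2-fold lower number from compound 2 to compound 3 (0.07 log units; within the scatter) and so leaves the number unmoved, while replacing ethylamino with the same ring gives a 1.0-fold lower number from compound 1 to compound 3 (0.02 log units; within the scatter) and also leaves it unmoved, so neither the ring nor its size matters among these three compounds. Nothing available explains why these swaps make so little difference. From the compounds shown here alone, whether this tolerance extends to very different groups on that carbonyl carbon, such as a carboxylic acid or a longer chain like hexylamino, remains open. The compounds shown also leave open whether any change to the shared core would move the number further than these swaps did.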